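Replacing the biaryl chloroaryl with a pyrrole

The source may hold more compounds than are shown below. What is called first, only, known or untested is meant among the compounds shown, and "the series" means these compounds.

Compound 2 `O=C(O)C[C@@](O)(C[C@H](O)CCCCCCc1ccc(Cl)cc1-c1ccc(Cl)cc1Cl)C(=O)O` gives 21000 nM in an assay on isolated protein for inhibition of ATP-citrate synthase (Homo sapiens) (on this read-out lower numbers stand for stronger inhibition and higher numbers for weaker inhibition), the higher of the two numbers in hand; its nearest neighbour is compound 1 `O=C(O)C[C@@](O)(C[C@H](O)CCCCCCc1ccc(Cl)cc1-c1ccc(F)cc1)C(=O)O`, which gives 2700 nM in this assay. Going by the values given here, the one step known, a 7.8-fold higher number from compound 1 to compound 2 (0.89 log units; beyond the scatter), went with a 2,4-dichlorophenyl taking the place of a 4-fluorophenyl. Compound 3 `O=C(O)C[C@@](O)(C[C@H](O)CCCCCCc1ccc(Cl)cc1-n1cccc1)C(=O)O` is not yet measured; it differs from compound 2 by 1H-pyrrol-1-yl in place of 2,4-dichlorophenyl on an aromatic carbon. Among the compounds with values here, only the step from compound 1 to compound 2 bears on this change, and it bears only loosely, since a pyrrol-1-yl is neither of the two aryl groups compared there. Given that moving from 4-fluorophenyl to 2,4-dichlorophenyl gave a 7.8-fold higher number from compound 1 to compound 2 (0.89 log units; beyond the scatter), a step back toward the number of compound 1 is expected for compound 3, estimated as a 4.7-fold lower number from compound 2 to compound 3 (0.67 log units; beyond the scatter), though with wide uncertainty. Compound 3 is estimated at 4500 nM, within 1300 nM to 15000 nM.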

Compound 3, inhibition constant: 3900 nM
Estimate against measurement, compound 3: 1.2-fold (0.06 log units) above; low and high end bracket the measured number.
By their numbers in this assay, from the lowest: compounds 1 and 3 (each within the scatter of the next); then compound 2.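

In this assay, this aromatic carbon does not require a six-membered aromatic ring of carbon only: 1H-pyrrol-1-yl, a five-membered aromatic ring with 1 hetero atom, gives a 5.4-fold lower number from compound 2 to compound 3 (0.73 log units; beyond the scatter) and a 1.4-fold higher number from compound 1 to compound 3 (0.16 log units; within the scatter). Compound 3 and compound 1 therefore cannot be told apart here, although the rings they carry differ in size and atom type. Of the three groups at this carbon, only 2,4-dichlorophenyl stands apart beyond the scatter, and no measurement in hand accounts for that.

On these data alone, it remains open which of the two chlorines in 2,4-dichlorophenyl goes with the higher number of compound 2. Also open, as far as these compounds go, is whether a pyridine ring or a saturated piperidine ring at this carbon would give numbers like those of compound 1 and compound 3.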